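Small carbamate in place of urea on the shared core

The compounds below may be only part of what the source reports. "The series", "measured", "known", "first", "only" and "open" are said of these compounds alone.

Of the compounds shown here, three sharing one core have been measured in an assay on isolated protein for displacement of a labelled ligand from 5-hydroxytryptamine receptor 6 (Homo sapiens); a higher number here means a weaker inhibitor, a lower number a stronger inhibitor. Compound 1 `O=C(NC[C@@H]1CCCc2cc(S(=O)(=O)c3cccc(F)c3)ccc21)c1ccc[nH]1` gives 5.01 nM in this assay. Compound 2 `O=C(NC[C@@H]1CCCc2cc(S(=O)(=O)c3cccc(F)c3)ccc21)[C@H]1CCCN1` gives 0.631 nM. Compound 3 `CN(C[C@@H]1CCCc2cc(S(=O)(=O)c3cccc(F)c3)ccc21)C(N)=O` gives 39.8 nM, the highest of the three numbers, which makes it the weakest binder here; the nearest is compound 1, as the step of a 7.9-fold higher number from compound 1 to compound 3 (0.90 log units; beyond the scatter) shows, and the furthest is compound 2, as the step of a 63-fold higher number from compound 2 to compound 3 (1.80 log units; beyond the scatter) shows.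

Compound 4 `COC(=O)NC[C@@H]1CCCc2cc(S(=O)(=O)c3cccc(F)c3)ccc21` differs from compound 3 by (methoxycarbonyl)amino in place of carbamoyl(methyl)amino on a saturated chain carbon bound to a saturated ring carbon. Both steps that end at compound 3 replaced a larger ring-bearing amide with the small urea and raised the number. The change to compound 4 keeps a group of the same small size, so neither step speaks directly to it. A step of at most modest size is expected in this assay, a 1.6-fold lower number from compound 3 to compound 4 (0.20 log units; within the scatter), leaning toward a lower number since the hydrogen-bond donor is retained. Compound 4 is estimated at 25 nM, within 8 nM to 80 nM.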

Compound 4, inhibition constant: 1.59 nM
For compound 4 the middle estimate is 16-fold (1.20 log units) above the measured one, outside the stated range (below it).
By their numbers in this assay, from the lowest: compound 2; then compound 4; then compound 1; then compound 3.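

Even between two small groups with the same heavy-atom count, this position in this assay is far from indifferent to the change (see a 25-fold lower number from compound 3 to compound 4 (1.40 log units; beyond the scatter)). The small (methoxycarbonyl)amino group also shows that no ring on the carbonyl carbon is needed for a low number: methoxy beats 1H-pyrrol-2-yl (a 3.2-fold lower number from compound 1 to compound 4 (0.50 log units; beyond the scatter)), although it falls short of pyrrolidin-2-yl (a 2.5-fold higher number from compound 2 to compound 4 (0.40 log units; beyond the scatter)). Nothing measured here explains these differences.

Compound 3 and compound 4 differ in two features at once, the methyl on the nitrogen and the group on the carbonyl, so a plain carbamoylamino group would be needed to separate them. From the compounds shown here alone, whether a longer chain such as ethoxy, or an amine such as dimethylamino, would work in place of methoxy also remains open.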